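The source may hold more compounds than are shown below. What is called first, only, known or untested is meant among the compounds shown, and "the series" means these compounds.

Measured compounds:
- compound 1 `CC(=O)C1=C(C)NC(=O)NC1c1ccoc1`: in an assay on membranes from CHO cells for displacement of a labelled ligand from adenosine receptor A1 (Homo sapiens), read by scintillation counting, with a stated time of 60 min, tested at 1 uM (a lower number here means less inhibition, a higher number more inhibition at the concentration tested (going by the name of the read-out)), compound 1 gives 6%
- compound 2 `CCCC(=O)C1=C(C)NC(=O)NC1c1ccoc1`: compound 2 gives 1%

Compound 2 stands lowest of the two numbers in this assay; its nearest neighbour is compound 1, and the gap between them is within the scatter. Within the data shown here, the only measured step, a number 5 percentage points lower from compound 1 to compound 2 (within the scatter), is an ethyl in place of hydrogen on a saturated chain carbon bound to a carbonyl carbon, and it lies within the scatter, so nothing so far shows that the group on the carbonyl moves the read-out.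

Compound 3 `CCN(CC)C(=O)C1=C(C)NC(=O)NC1c1ccoc1` is the next candidate. It differs from compound 2 by diethylamino in place of propyl on a carbonyl carbon. This change touches the same carbonyl position as the step from compound 1 to compound 2, but it exchanges the chain for diethylamino rather than lengthening it, so the earlier step bears on it only loosely. Among the measured compounds shown here, with both measured values low and the one known step flat, no step beyond the scatter is expected in this assay; the step from compound 2 to compound 3 is expected to be a number 3 percentage points higher from compound 2 to compound 3 (within the scatter). For compound 3 the estimated value is 4%, within -8% to 16%.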

Compound 3, a percentage reported as inhibition, at one concentration (the size of the read-out at that concentration, not a potency): 15%
For compound 3 the middle estimate is 11 percentage points below the measured one; low and high end bracket the measured number.
By their numbers in this assay, from the lowest: compounds 2, 1 and 3 (each within the scatter of the next, the first and the last beyond it).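

In this assay the carbonyl carbon, whose other neighbours are the double-bonded ring carbon, now gives its first step beyond the scatter (a number 14 percentage points higher from compound 2 to compound 3 (beyond the scatter)), a modest one, for diethylamino in place of propyl. Against the methyl group the same exchange does not clear the scatter (a number 9 percentage points higher from compound 1 to compound 3 (within the scatter)), so the effect of diethylamino at this position is seen against propyl alone and cannot yet be called general across the carbonyl substituents shown. The group on this carbonyl carbon can therefore matter to the read-out, although the inhibition remains small at the one concentration tested, and nothing measured alongside these numbers bears on the reason for the step.

The compounds shown leave open whether the step belongs to the nitrogen on the carbonyl or to the two ethyl groups it carries, a question that ethylamino, dimethylamino or a piperidine amide would help to separate. They also leave open whether larger amines, such as dipropylamino, carry the read-out further at this position or leave it where diethylamino puts it.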